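The source may report more compounds than this note shows. Statements on the series, on what has been measured and on what is new or still open speak of the compounds shown alone.

Compound 3 `Cc1ncc(CO)c2c(Nc3ccccn3)c(N[C@@H](C)c3ccccc3)oc12` shares its core with compound 2 `Cc1ncc(CO)c2c(Nc3ccccn3)c(NC[Si](C)(C)C)oc12`; the two differ only in the group on the nitrogen on the aromatic ring. In a functional assay on HEK293 cells for agonist activity at Toll-like receptor 8 (Homo sapiens), read by reporter gene assay (on this read-out higher numbers stand for an effect only at larger amounts of compound and lower numbers for an effect already at smaller amounts), compound 3 gives 4270 nM, and compound 2 gives 4990 nM. These two values lie within the scatter of each other, and the corresponding step of a 1.2-fold lower number from compound 2 to compound 3 (0.07 log units; within the scatter) is within the scatter as well, so the numbers do not separate them. Compound 1 `Cc1ncc(CO)c(-c2nc3ccccn3c2NC2CCCCC2)c1OCc1ccccc1`, built on a different core, gives "not active" (no number reported) in this assay and so contributes no number.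

Compound 4 `Cc1ncc(CO)c2c(Nc3ccccn3)c(NCc3ccccc3)oc12` is the next step from compound 3: hydrogen in place of methyl on a saturated chain carbon bound to an aromatic carbon and a nitrogen on an aromatic ring. Among the measured compounds shown here, the only measured step, the exchange of the whole group on the nitrogen on the aromatic ring, moved the value only within the scatter; no step in this set tests the removal of a methyl on its own. No bearing on the direction is therefore available, and a change beyond the scatter is not expected. Compound 4 is estimated at 4300 nM, with a range from 1500 nM to 12000 nM. The expected step is a 1.0-fold higher number from compound 3 to compound 4 (0.00 log units; within the scatter), which is estimated to stay within the scatter.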

Compound 4, half-maximal effective concentration: 4910 nM
For compound 4 the middle estimate is 1.1-fold (0.06 log units) below the measured one; low and high end bracket the measured number.
By their numbers in this assay, from the lowest: compounds 3, 4 and 2 (each within the scatter of the next).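

Exchanging methyl for hydrogen on the saturated chain carbon, 1-phenylethyl to benzyl, gives a 1.1-fold higher number from compound 3 to compound 4 (0.06 log units; within the scatter) in this assay. Among the compounds shown here, this is the first step in the set that tests that methyl on its own, and at this position the numbers do not separate the two groups. The wider exchange of the ring-free silicon group for the benzyl group, on the saturated chain carbon, gives a 1.0-fold lower number from compound 2 to compound 4 (0.01 log units; within the scatter), and no information is available that bears on why these values lie so close.

The compounds shown leave open whether a longer chain such as pentyl, or a group carrying an amine or a carboxylic acid, would give a number beyond the scatter in place of benzyl. They also leave open how the mirror-image form of the 1-phenylethyl group would read.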